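Cytotoxicity of compound 1 and its piperazine variant

The source may report more compounds than this note shows. Statements on the series, on what has been measured and on what is new or still open speak of the compounds shown alone.

Compound 1 `CCCCC(=O)Nc1ccc(S(=O)(=O)N(CC(N)=O)c2ccc(N(CC(N)=O)S(=O)(=O)c3ccc(OC)cc3)c3ccccc23)cc1` is the starting point. In a functional assay on cells (Peritoneal macrophage, Mus musculus) for cytotoxicity, with a stated time of 24 h (a higher number here means that more compound is tolerated, a lower number that less compound is tolerated), compound 1 gives > 100000 nM, which is a limit of the assay rather than a number. Compound 2 `COc1ccc(S(=O)(=O)N(CC(N)=O)c2ccc(N(CC(N)=O)S(=O)(=O)c3ccc(NC(=O)CCN4CCC(C)CC4)cc3)c3ccccc23)cc1` also reaches only a limit, with > 100000 nM. Compound 3 `COc1ccc(S(=O)(=O)N(CC(N)=O)c2ccc(N(CC(N)=O)S(=O)(=O)c3ccc(NC(=O)CCN4CCN(C(C)C)CC4)cc3)c3ccccc23)cc1` likewise gives > 100000 nM, again a limit. Within the data shown here, the steps a step that the two limits leave unreadable from compound 1 to compound 2 and a step that the two limits leave unreadable from compound 1 to compound 3 therefore cannot be sized, and the limit of > 100000 nM in this assay, at which 3 of the 3 values shown sit, is the only evidence available. Compound 4 `CCN1CCN(CCCC(=O)Nc2ccc(S(=O)(=O)N(CC(N)=O)c3ccc(N(CC(N)=O)S(=O)(=O)c4ccc(OC)cc4)c4ccccc34)cc2)CC1` differs from compound 1 by 4-ethylpiperazin-1-yl in place of methyl on a saturated chain carbon, three bonds along the chain from a carbonyl carbon. Because every measured step sits at the limit of > 100000 nM in this assay, at which 3 of the 3 values shown sit, no direction can be read for the new change. For compound 4 the expected step is a number no higher from compound 1 to compound 4 (the limit leaves the size open), most likely ending at the same limit. Compound 4 is estimated at 100000 nM, between 50000 nM and 300000 nM.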

Compound 4, half-maximal cytotoxic concentration: > 100000 nM
Compound 4: a limit, no number (the forecaster's own chance of this, stated with the estimate: 85%); the middle value sits exactly at the limit.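

Compound 4 ends at a limit, as do compound 1, compound 2 and compound 3, so no step among them can be read: the limit of > 100000 nM in this assay, at which 4 of the 4 values shown sit.

The compounds shown leave open whether any change to the side chain alters the outcome in this assay.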